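A few compounds are considered here, and "the series" means these few. Any claim that something is new, unique, unknown or untested is made for them only; others in the source may bear on it.

Working notes on the series. Compound 1 `COc1ccc(-c2cc(/C=C/C(=O)c3ccc(N)cc3)[nH]n2)cc1` gives 4920 nM in a functional assay on OVCAR-5 cells (Homo sapiens) for inhibition, read by sulforhodamine B assay, with a stated time of 48 h; a higher number here means a weaker inhibitor of growth, a lower number a stronger inhibitor of growth. Compound 2 `COc1cc(-c2cc(/C=C/C(=O)c3ccc(Cl)c(Cl)c3)[nH]n2)cc(OC)c1OC` in this assay returns only a limit, > 100000 nM, so its standing is known as a limit and nothing more, as recorded in the limit of > 100000 nM in this assay, at which 1 of the 2 values shown sits. Compound 3 `COc1ccc(C(=O)/C=C/c2cc(-c3cc(OC)c(OC)c(OC)c3)n[nH]2)cc1` differs from compound 2 by 4-methoxyphenyl in place of 3,4-dichlorophenyl on a carbonyl carbon. Among the measured compounds shown here, no measured step of this kind exists in the set, so the direction rests on compound 1 alone, whose methoxyphenyl-bearing analogue sits at a real number rather than a limit. The expected step is an at least 3.3-fold lower number from compound 2 to compound 3 (0.52 log units; beyond the scatter), toward stronger inhibition and beyond the scatter, with wide uncertainty. Compound 3 is estimated at 30000 nM, between 5000 nM and 150000 nM.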

Compound 3, concentration for total growth inhibition: 3780 nM
The estimate for compound 3 lay 7.9-fold (0.90 log units) above the measured number; the measured number lies below the stated range.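

On the carbonyl carbon, 4-methoxyphenyl in place of 3,4-dichlorophenyl brings a measurable reading in this assay, with an at least 26-fold lower number from compound 2 to compound 3 (1.42 log units; beyond the scatter). Among the compounds shown here, this is the first step at this position, and it fixes only the direction and a minimum size. The true size stays unknown because compound 2 stands at a limit: the limit of > 100000 nM in this assay, at which 1 of the 3 values shown sits.

From the compounds shown here alone, whether the difference follows the methoxy group's arrival or the chlorines' departure remains open. Unsubstituted phenyl or 4-chlorophenyl on the same carbonyl carbon of the core of compound 3 would help separate the two.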